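Chloro to hydrogen on the shared core: working notes

This account rests on a few compounds, and the source may have more. Where it says the series, first, only, none or still open, it means among the compounds named here.

Measured so far:
compound 1, `ClCc1ccccc1Cn1cnc2c(Cl)nc(Cl)nc21`: 1860 nM
compound 2, `ClCc1ccccc1Cn1cnc2c(Cl)ncnc21`: 17800 nM
compound 3, `ClCc1ccc(Cn2cnc3nc(Cl)nc(Cl)c32)cc1`: 1900 nM

In a functional assay on 786-0 cells (Homo sapiens) for cytotoxicity, read by sulforhodamine B assay, with a stated time of 48 h (on this read-out higher numbers stand for weaker inhibition of growth and lower numbers for stronger inhibition of growth), compound 1 gives 1860 nM and compound 2 gives 17800 nM. The change between them, (hydrogen in place of chloro on an aromatic carbon), produces a 9.6-fold higher number from compound 1 to compound 2 (0.98 log units; beyond the scatter). Compound 3 gives 1900 nM in this assay; how its core differs from that of compound 1 is not broken down here, and the two values lie within the usual scatter of each other, so no order between them is claimed.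

Compound 4, `ClCc1ccc(Cn2cnc3ncnc(Cl)c32)cc1`, has not yet been measured. It differs from compound 3 by hydrogen in place of chloro on an aromatic carbon, which is the same change as that from compound 1 to compound 2, at a place described in the same words. For compound 4 in this assay the expected step is a 9.5-fold higher number from compound 3 to compound 4 (0.98 log units; beyond the scatter), and this expectation rests on a 9.6-fold higher number from compound 1 to compound 2 (0.98 log units; beyond the scatter), the one earlier occurrence of the change among these compounds. Compound 4 is therefore estimated to give about 18000 nM in this assay, with a likely range from 8000 nM to 40000 nM.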

Compound 4, concentration for 50% growth inhibition: 1690 nM
Estimate against measurement, compound 4: 11-fold (1.03 log units) above; the measured number lies below the stated range.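

In this assay, hydrogen in place of chloro on an aromatic carbon gives a 1.1-fold lower number from compound 3 to compound 4 (0.05 log units; within the scatter), which is within the scatter, and the same change on the core of compound 1 does not stay within it: the same change on two cores in this assay, a 9.6-fold higher number (0.98 log units; beyond the scatter) from compound 1 to compound 2 and a 1.1-fold lower number (0.05 log units; within the scatter) from compound 3 to compound 4, 11-fold (1.03 log units) apart, beyond the scatter of two such steps. The step therefore does not carry from one core to the other in this series, and the size of the change on one core is no safe guide to its size on the other. These two pairs do not show why the steps part, and two occurrences of the change are too few for any rule about which cores would keep the larger step.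

The compounds shown leave open how an amine or a methoxy group on that aromatic carbon, between two ring nitrogen atoms, would read on either core. Also open, from the compounds shown here alone, is whether the two steps part in the same way in any other cell line.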